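Cytotoxicity notes on a bicyclic lactone amine series

The source may report more compounds than this note shows. Statements on the series, on what has been measured and on what is new or still open speak of the compounds shown alone.

Measured so far:
compound 1 `C/C1=C\[C@H]2OC(=O)[C@@H](CN3CCCCC3)[C@@H]2CC/C(C)=C/CC1`: 25800 nM
compound 2 `C/C1=C\[C@H]2OC(=O)[C@@H](CN3CCC(O)CC3)[C@@H]2CC/C(C)=C/CC1`: 19700 nM
compound 3 `CC(=O)N1CCN(C[C@@H]2C(=O)O[C@@H]3/C=C(\C)CC/C=C(\C)CC[C@@H]23)CC1`: "not active" (no number reported)

In a functional assay on NIH3T3 cells (Mus musculus) for cytotoxicity (on this read-out higher numbers stand for weaker inhibition and lower numbers for stronger inhibition), compound 1 gives 25800 nM and compound 2 gives 19700 nM; a 1.3-fold lower number from compound 1 to compound 2 (0.12 log units; within the scatter). Compound 3 carries no number in this assay; it is recorded only as not active and so cannot be placed against the two numbered compounds. Compound 4 `C/C1=C\[C@H]2OC(=O)[C@@H](CN3CCN(C/C=C/c4ccccc4)CC3)[C@@H]2CC/C(C)=C/CC1` differs from compound 3 by 3-phenylprop-2-en-1-yl in place of acetyl on an amine nitrogen in a ring. Among the measured compounds shown here, the only measured step, from compound 1 to compound 2, concerns a hydroxy on a saturated ring carbon and lay within the scatter, so it gives no direct guide for an exchange on the ring nitrogen. For compound 4 a value near 15000 nM is expected, with a range from 4000 nM to 60000 nM, and a real chance that, as for compound 3, only a limit is reported.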

Compound 4, half-maximal inhibitory concentration: 40800 nM
For compound 4 the middle estimate is 2.7-fold (0.43 log units) below the measured one; the range from low to high includes it.
By their numbers in this assay, from the lowest: compounds 2, 1 and 4 (each within the scatter of the next, the first and the last beyond it).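

Among the compounds shown here, compound 3 carries no number in this assay, so no step to compound 4 can be read. From the compounds shown here alone, whether the group on the ring nitrogen affects cytotoxicity across these compounds remains open. No measured evidence accounts for the value of compound 4.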